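From Compound 1 to Compound 4: an Untested Change

The compounds below may be only part of what the source reports. "The series", "measured", "known", "first", "only" and "open" are said of these compounds alone.

Compound 1 `Cc1ccsc1-c1ccccc1NCC1=NCCN1` gives 112 nM in a functional assay for activation of Alpha-1B adrenergic receptor (Homo sapiens), read by calcium flux; on this read-out lower numbers stand for an effect already at smaller amounts and higher numbers for an effect only at larger amounts of compound.
Compound 2 `Cc1cccnc1-c1ccccc1NCC1=NCCN1` gives < 100000 nM; this is a limit of the assay, not a number.
Compound 3 `Nc1nccc(-c2ccccc2NCC2=NCCN2)n1` gives < 5020 nM; this too is a limit, not a number.

Among the three measured compounds, compound 1 is the only one with a definite number in this assay; the other two stand at limits, one at the limit of < 100000 nM in this assay, at which 1 of the 3 values shown sits, and one at the limit of < 5020 nM in this assay, at which 1 of the 3 values shown sits, so they cannot be set against compound 1 in size.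

Compound 4 `CCO/N=C(\C)c1ccccc1NCC1=NCCN1` has not yet been measured. It differs from compound 1 in one place: a group of 6 heavy atoms (4 carbon, 1 nitrogen, 1 oxygen; no ring) in place of a group of 6 heavy atoms (5 carbon, 1 sulfur; one five-membered aromatic ring with 1 hetero atom), on an aromatic carbon. Among the measured compounds shown here, no step between two measured compounds shows what such a swap of a five-membered aromatic ring for an open chain does here, so the expectation rests on compound 1 alone. A moderate loss, beyond the usual scatter, is expected, with the step from compound 1 to compound 4 estimated at a 4.0-fold higher number from compound 1 to compound 4 (0.60 log units; beyond the scatter). Compound 4 is therefore expected to give about 450 nM, within a range from 90 nM to 2500 nM.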

Compound 4, half-maximal effective concentration: < 5020 nM
Compound 4 was reported as a limit; the forecaster's own chance of this, stated with the estimate: 10%; the middle value does not contradict the limit.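

Among the compounds shown here, the result for compound 4 is a limit of the assay, not a number, so no step from compound 1 to compound 4 can be read. The compounds shown leave open how large a change comes from replacing the 3-methylthiophen-2-yl group with the open chain.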